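This account rests on a few compounds, and the source may have more. Where it says the series, first, only, none or still open, it means among the compounds named here.

Compounds measured in an assay on cells for inhibition of Palmitoleoyl-protein carboxylesterase NOTUM variant C330S (Homo sapiens), read by fluorescence, with a stated time of 40 min; a higher number here means a weaker inhibitor, a lower number a stronger inhibitor:
- compound 1, `Cc1[nH]c(C(F)(F)F)cc1C(=O)O`: 6700 nM
- compound 2, `O=C(O)C1CCN(c2ccccc2Cl)C1`: 19000 nM
- compound 3, `Cc1cc(C(=O)O)c(C)n1-c1cccc(F)c1`: 1500 nM

Compound 3 stands lowest of the three in this assay; compound 1 gives a higher number and compound 2 a higher one still, both gaps lying beyond the scatter, so compound 3 is the strongest inhibitor of the set on the numbers shown. No pair of these compounds differs in one place only, so no step size is known.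

Compound 4, `Cc1cccc(-n2c(C)cc(C(=O)O)c2C)c1`, differs from compound 3 by methyl in place of fluoro on an aromatic carbon. Among the measured compounds shown here, with no measured step of this kind, the expectation rests on compound 3 alone: the change is expected to move the number no further than the scatter, no change at the digits printed from compound 3 to compound 4 (within the scatter). Compound 4 is therefore estimated at 1500 nM, with a range of 500 nM to 4500 nM.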

Compound 4, half-maximal inhibitory concentration: 1500 nM
Compound 4: middle estimate and measured number agree at the digits printed, within the range that was stated.
By their numbers in this assay, from the lowest: compounds 3 and 4 (each within the scatter of the next); then compound 1; then compound 2.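

In this assay, among the compounds shown here, methyl in place of fluoro on an aromatic carbon, meta to a large group, gives no change at the digits printed from compound 3 to compound 4 (within the scatter), the only step so far between compounds differing in one place. At this position on the six-membered aromatic ring of carbon only, this exchange therefore leaves the reading within the scatter. Nothing available explains this result.

Still open, from the compounds shown here alone, is how a larger or different group at this position, such as an amine or a methoxy group, would read. Also open, going by these compounds, is what an amide in place of the carboxylic acid would do.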